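The source may report more compounds than this note shows. Statements on the series, on what has been measured and on what is new or still open speak of the compounds shown alone.

Working notes on the series, read in a functional assay on HL-60 cells (Homo sapiens) for cytotoxicity, read by WST assay, with a stated time of 48 h; on this read-out higher numbers stand for an effect only at larger amounts of compound and lower numbers for an effect already at smaller amounts. Compound 1 (`COc1ccccc1C[C@H]1COC(=O)[C@@H]1Cc1ccc(Cl)c(Cl)c1`) gives 14000 nM, and compound 2 (`Cc1ccc(C[C@H]2COC(=O)[C@@H]2Cc2ccc(Cl)c(Cl)c2)cc1`) gives 19000 nM. Among the compounds with values here, these are the only two numbers so far, and they lie within the scatter of each other, so compound 2 stands level with compound 1.

The next change leads to compound 3 (`O=C1OC[C@H](Cc2ccc(Cl)c(Cl)c2)[C@H]1Cc1ccc(Cl)c(Cl)c1`), with 3,4-dichlorophenyl in place of 4-methylphenyl on a saturated chain carbon bound to a saturated ring carbon.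

Within the data shown here, only one measured step bears on this place. Going from 2-methoxyphenyl to 4-methylphenyl there gave a 1.4-fold higher number from compound 1 to compound 2 (0.13 log units; within the scatter). Among the measured compounds shown here, that single step is small, but no measured compound carries 3,4-dichlorophenyl at this place, so the evidence is thin and the range has to stay wide. With the exchange of groups at this place having moved the number by no more than the scatter in compound 2 (19000 nM), no step beyond the scatter is expected in this assay, and no firm direction can be assigned. The expected step is a 1.3-fold lower number from compound 2 to compound 3 (0.10 log units; within the scatter). Compound 3 is estimated at 15000 nM, with an expected range of 6000 nM to 40000 nM.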

Compound 3, half-maximal effective concentration: 20000 nM
Estimate against measurement, compound 3: 1.3-fold (0.12 log units) below, and the stated range covers the measured number.
By their numbers in this assay, from the lowest: compounds 1, 2 and 3 (each within the scatter of the next).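

In this assay, the exchange at this place now spans three groups, and 3,4-dichlorophenyl on a saturated chain carbon bound to a saturated ring carbon stands level with both earlier groups: the step to it from 4-methylphenyl is a 1.1-fold higher number from compound 2 to compound 3 (0.02 log units; within the scatter), and the step to it from 2-methoxyphenyl is a 1.4-fold higher number from compound 1 to compound 3 (0.15 log units; within the scatter). The level reading from the earlier pair therefore extends to a group with two chlorine atoms and no oxygen, and compound 3 shows that 3,4-dichlorophenyl can stand on both chains of the shared core without a step beyond the scatter. No measurement at hand offers an explanation for this flat result.

All three groups shown at this place are six-membered aromatic rings of carbon only, so it remains open whether an amine, a carboxylic acid or a longer chain there would give a step beyond the scatter. Also open, as far as these compounds go, is whether a compound with a much lower number can be reached by changing this place at all, or whether such a step would need a change elsewhere on the shared core.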